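From 4-chlorophenyl to 3-fluorophenyl at the histamine H2 receptor

This account rests on a few compounds, and the source may have more. Where it says the series, first, only, none or still open, it means among the compounds named here.

Compound 1, `Cc1nc(N)sc1CCCN/C(N)=N/C(=O)NC(C)c1ccc(Cl)cc1`: 46.8 nM
Compound 2, `Cc1nc(N)sc1CCCN/C(N)=N/C(=O)Nc1ccccc1`: 3160 nM

Of the compounds shown here, two have been measured in an assay on membranes from Sf9 cells for displacement of a labelled ligand from histamine H2 receptor (Homo sapiens), read by scintillation counting, with a stated time of 60 min; a higher number here means a weaker inhibitor, a lower number a stronger inhibitor. Compound 1 gives 46.8 nM, the lowest number of the two, and so the stronger inhibitor. Compound 2 gives 3160 nM, a number far beyond the scatter of the method away from compound 1; the two differ in more than one place, so the gap cannot be tied to a single change.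

Compound 3, `Cc1nc(N)sc1CCCN/C(N)=N/C(=O)NC(C)c1cccc(F)c1`, is not yet measured. It differs from compound 1 by a single change: 3-fluorophenyl in place of 4-chlorophenyl on a saturated chain carbon bound to an amide-type nitrogen and a saturated chain carbon. Among the measured compounds shown here, no measured pair shows what such a swap does here, so nothing firm can be drawn from the numbers. A small step is expected from compound 1 to compound 3, a 1.9-fold higher number from compound 1 to compound 3 (0.28 log units; within the scatter), toward a somewhat higher number and quite possibly within the scatter. Compound 3 is therefore estimated at 90 nM, with a range from 30 nM to 300 nM.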

Compound 3, inhibition constant: 2.04 nM
For compound 3 the middle estimate is 44-fold (1.64 log units) above the measured one, and the stated range ends above it.
By their numbers in this assay, from the lowest: compound 3; then compound 1; then compound 2.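

Replacing 4-chlorophenyl with 3-fluorophenyl on the saturated chain carbon gives, in this assay, a 23-fold lower number from compound 1 to compound 3 (1.36 log units; beyond the scatter), making compound 3 the stronger inhibitor of this pair. This position is therefore highly sensitive: two groups of equal heavy-atom count, with the same ring and no hydrogen-bond donors or acceptors, give clearly different results. No measurement shown explains the gain.

Among the compounds shown here, the single step changes both the halogen and its place on the ring, so it cannot show which of the two matters more; a 3-chlorophenyl or 4-fluorophenyl group at this position would help separate them. On these data alone, whether an unsubstituted phenyl group on this same chain carbon would give a higher or lower number than either halogenated ring also remains open.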